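Alkylidene versus methylene link to the hydantoin ring

A few compounds are considered here, and "the series" means these few. Any claim that something is new, unique, unknown or untested is made for them only; others in the source may bear on it.

Measured compounds:
compound 1, `CC(C)C(CC1C(=O)NC(=O)N1C)c1ccc(-c2ccc3cccc(F)c3c2)[nH]c1=O`, a functional assay on CHO cells for antagonist activity at prostaglandin E2 receptor EP3 subtype (Homo sapiens), read by cAMP accumulation, with a stated time of 30 min; on this read-out lower numbers stand for stronger inhibition and higher numbers for weaker inhibition: 65 nM
compound 2, `CC(C)[C@@H](c1ccc(-c2ccc3cccc(F)c3c2)[nH]c1=O)[C@@H]1OC(=O)NC1=O`, this assay: 610 nM
compound 3, `O=C1NC(=O)/C(=C/C(c2ccc(-c3ccc4cccc(F)c4c3)[nH]c2=O)C2CCCC2)O1`, this assay: 7 nM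

Compound 1 stands second highest of the three numbers. The nearest is compound 3, whose number is lower by a margin beyond the scatter; the furthest is compound 2, whose number is higher, again beyond the scatter. For the measured compounds named here, compound 2 and compound 3 are the only pair carrying a five-membered ring of the same type, and they differ in several places at once, so their gap cannot be assigned to one change.

Compound 4, `CC(C)C(/C=C1/C(=O)NC(=O)N1C)c1ccc(-c2ccc3cccc(F)c3c2)[nH]c1=O`, keeps the core of compound 1 and changes the link to the hydantoin: a group of 9 heavy atoms (5 carbon, 2 nitrogen, 2 oxygen; one five-membered non-aromatic ring with 2 hetero atoms) in place of a group of 9 heavy atoms (5 carbon, 2 nitrogen, 2 oxygen; one five-membered non-aromatic ring with 2 hetero atoms), on a saturated chain carbon bound to an aromatic carbon and a saturated chain carbon. The entering group carries one more double bond outside aromatic rings than the leaving group, which also means the saturated chain carbon bearing it now sits in a double bond to the ring.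

Going by the values given here, no measured pair shows this change in isolation. Compound 3 shows that a ring attached through a double bond is compatible with the lowest number in the set, so for compound 4 a step from compound 1 to a lower number is expected, of modest size, and it is estimated at a 2.6-fold lower number from compound 1 to compound 4 (0.41 log units; beyond the scatter). Compound 4 is expected at 25 nM, within 8 nM to 80 nM.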

Compound 4, half-maximal inhibitory concentration: 11 nM
Compound 4: the middle estimate sits 2.3-fold (0.36 log units) above what was measured; measured number inside the range.
By their numbers in this assay, from the lowest: compounds 3 and 4 (each within the scatter of the next); then compound 1; then compound 2.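

Within this assay the replacement of (3-methyl-2,5-dioxoimidazolidin-4-yl)methyl on the saturated chain carbon gives a 5.9-fold lower number from compound 1 to compound 4 (0.77 log units; beyond the scatter), the first step in the series that can be read at a single place. The heavy-atom, donor and acceptor counts of the group stay the same, so the change counted here is one more double bond outside aromatic rings, and at this place that double bond goes with the lower number. No measurement on hand accounts for the size of this step.

Open, going by these compounds, is whether the same change gives a similar step on the ring type of compound 2 and compound 3, or with a different chain group on the shared core. Also open, on these data alone, is how a longer chain in the link to the hydantoin, or a carboxylic acid in place of the hydantoin, would read in this assay.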